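Swapping Phenyl for Anilino on the Carbonyl Carbon

The source may hold more compounds than are shown below. What is called first, only, known or untested is meant among the compounds shown, and "the series" means these compounds.

Compound 1 `COc1ccc(-c2nc(NC(=O)c3ccccc3)n(-c3ccccc3)n2)cc1` stands lowest of the two compounds measured in an assay on CHO cells for displacement of a labelled ligand from adenosine receptor A1 (Homo sapiens), tested at 10 uM; on this read-out lower numbers stand for less inhibition and higher numbers for more inhibition at the one concentration tested (going by the name of the read-out): compound 1 gives 25%. Compound 2 `COc1ccc(-c2nc(N(C(=O)c3ccccc3)C(=O)c3ccccc3)n(-c3ccccc3)n2)cc1` gives 55%. Going by the values given here, the only measured step is a number 30 percentage points higher from compound 1 to compound 2 (beyond the scatter), a change at a different place. Compound 3 `COc1ccc(-c2nc(NC(=O)Nc3ccccc3)n(-c3ccccc3)n2)cc1` differs from compound 1 in one spot: anilino in place of phenyl on a carbonyl carbon. Among the compounds with values here, no measured step touches this part of the molecule, so the change is untested and the expectation leans on compound 1 alone. A step of a number 3 percentage points higher from compound 1 to compound 3 (within the scatter) is therefore expected, nothing beyond the scatter. Compound 3 is estimated at 28%, between 5% and 60%.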

Compound 3, a percentage reported as inhibition, at one concentration (the size of the read-out at that concentration, not a potency): 1%
Beside the measured number, compound 3's estimate is 27 percentage points above it, outside the stated range (below it).
By their numbers in this assay, from the lowest: compound 3; then compound 1; then compound 2.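

In this assay, the group on this carbonyl carbon matters: anilino in place of phenyl gives a number 24 percentage points lower from compound 1 to compound 3 (beyond the scatter), even though the two groups share the same aromatic ring. The swap, which can also be read as phenylcarbamoyl in place of benzoyl, adds one nitrogen and one hydrogen-bond donor, and this small edit is enough to move the number beyond the scatter. No available evidence explains this drop. 

Going by these compounds, it remains open how a phenoxy or benzyl group on this carbonyl carbon would read, and so whether this result is specific to the nitrogen of anilino or would follow from any linking atom.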